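The compounds below may be only part of what the source reports. "The series", "measured", "known", "first", "only" and "open" are said of these compounds alone.

Measured compounds:
compound 1 `Nc1cccc(-c2csc(NC(=O)CCCCCC(=O)Nc3ccccc3N)n2)c1` — 2910 nM
compound 2 `CC(C)(C)OC(=O)Nc1cccc(-c2csc(NC(=O)CCCCCC(=O)NO)n2)c1` — 5.7 nM
compound 3 `CCOC(=O)Nc1cccc(-c2csc(NC(=O)CCCCCC(=O)NO)n2)c1` — 2.1 nM

In an assay on isolated protein for inhibition of polyamine deacetylase HDAC10 (Homo sapiens), read by fluorescence, with a stated time of 17 h (on this read-out lower numbers stand for stronger inhibition and higher numbers for weaker inhibition), compound 3 gives 2.1 nM, the lowest of the three numbers shown. Compound 2 sits nearest to it, and compound 1 lies far above both. Compound 4 `Nc1cccc(-c2csc(NC(=O)CCCCCC(=O)NO)n2)c1` has not yet been measured. It differs from compound 3 in one place: hydrogen in place of ethoxycarbonyl on a nitrogen on an aromatic ring. Among the compounds with values here, only one measured step touches this region of the molecule: the change a 2.7-fold lower number from compound 2 to compound 3 (0.43 log units; beyond the scatter), where one ester group on the carbamate was swapped for another while the carbamate itself stayed in place. Within the data shown here, no measured pair shows what happens when the whole ethoxycarbonyl group is removed. Compound 1 does carry the free amino group, but it also differs from compound 4 elsewhere, so its value alone cannot stand for this step. Since the two carbamate esters gave only a modest difference, and the free amine is a smaller cap, a moderate loss of potency is expected: the step of a 3.8-fold higher number from compound 3 to compound 4 (0.58 log units; beyond the scatter) is the estimate here. Compound 4 is therefore expected to give about 8 nM, within a range of 2 nM to 30 nM.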

Compound 4, half-maximal inhibitory concentration: 3.7 nM
For compound 4 the middle estimate is 2.2-fold (0.33 log units) above the measured one; low and high end bracket the measured number.
By their numbers in this assay, from the lowest: compounds 3, 4 and 2 (each within the scatter of the next, the first and the last beyond it); then compound 1.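

In this assay, the step of a 1.8-fold higher number from compound 3 to compound 4 (0.25 log units; within the scatter) removes the whole ethoxycarbonyl group from the nitrogen on the aromatic ring, and the step of a 1.5-fold lower number from compound 2 to compound 4 (0.19 log units; within the scatter) does the same with tert-butoxycarbonyl, so neither carbamate is needed for activity at this position. The group on the amide-type nitrogen counts for far more, as the step of a 790-fold lower number from compound 1 to compound 4 (2.90 log units; beyond the scatter) with hydroxy in place of 2-aminophenyl shows while the free amino group stays in place on both sides. Nothing shown gives a reason for either result and the numbers alone must stand.

Going by these compounds, it remains open whether this nitrogen would accept other groups, such as acetyl, methyl or a longer chain, with the same small effect on the number. A carboxylic acid in place of the amino group is also untested among the compounds shown here.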